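Swapping a methylphenyl for cyclohexyl on a carboxamide scaffold

The source may report more compounds than this note shows. Statements on the series, on what has been measured and on what is new or still open speak of the compounds shown alone.

Three compounds have numbers in an assay on ileum with muscarinic acetylcholine receptor M3 (Cavia porcellus) as the target; a lower number here means a stronger inhibitor, a higher number a weaker inhibitor:
compound 1 `Cc1nccn1CCC(O)(c1ccccc1)c1ccccc1` gives 16.7 nM
compound 2 `Cc1nccn1CCC(C(=O)N(C)C)(c1ccccc1)c1ccccc1` gives 258 nM
compound 3 `Cc1ccc(C(CCn2ccnc2C)(C(N)=O)c2ccccc2)cc1` gives 24.6 nM

Compound 3 stands second highest of the three numbers. Its nearest neighbour is compound 1, whose number differs from it by less than the scatter, so no order between these two can be claimed. Compound 2 is the furthest, with a number that lies beyond the scatter from compound 3.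

Compound 4 `Cc1nccn1CCC(C(N)=O)(c1ccccc1)C1CCCCC1` differs from compound 3 in one place: cyclohexyl in place of 4-methylphenyl on a saturated chain carbon bound to an aromatic carbon, a carbonyl carbon and a saturated chain carbon. For the measured compounds named here, none of the measured steps touches this place. Going by the values given here, the only step that was measured, a 15-fold higher number from compound 1 to compound 2 (1.19 log units; beyond the scatter), alters the group on the carbon that carries the two aromatic rings, not one of the rings themselves, and therefore gives no guide to the size or direction of the present change. Among the compounds with values here, with no step bearing on it, the expectation is a change of no more than the scatter in this assay. Compound 4 is accordingly expected to give about 15 nM, with a range from 3 nM to 60 nM. The expected step is a 1.6-fold lower number from compound 3 to compound 4 (0.21 log units; within the scatter).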

Compound 4, antagonist equilibrium constant: 19 nM
The estimate for compound 4 lay 1.3-fold (0.10 log units) below the measured number; low and high end bracket the measured number.
By their numbers in this assay, from the lowest: compounds 1, 4 and 3 (each within the scatter of the next); then compound 2.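

For the compounds shown here, exchanging the 4-methylphenyl for cyclohexyl on the saturated chain carbon that also carries the carboxamide gives, in this assay, a 1.3-fold lower number from compound 3 to compound 4 (0.11 log units; within the scatter), which is the first measured step at this place rather than at the group the earlier step altered. In this one pair, therefore, the six-membered ring at this place can be aromatic or non-aromatic, and can carry seven or six heavy atoms, without any difference that can be read beyond the scatter, so neither the aromatic ring nor its methyl group is shown to be needed here for a number in this range. Nothing available accounts for this match between the two rings, and the pair alone cannot say whether it reflects a general tolerance at this place.

The compounds shown leave open how far this tolerance extends, for instance to a cyclopentyl group, a piperidinyl ring carrying a basic amine, or an open n-hexyl chain at the same carbon. They also leave open whether the same exchange would read alike with a hydroxy or a dimethylcarbamoyl group in place of the carboxamide.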